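Pyrrolidin-1-yl in place of cyclopropylamino

The compounds below may be only part of what the source reports. "The series", "measured", "known", "first", "only" and "open" are said of these compounds alone.

In a functional assay on BXPC-3 cells (Homo sapiens) for cytotoxicity, read by fluorescence, with a stated time of 48 h (a higher number here means that more compound is needed for the effect, a lower number that less compound is needed), compound 2 `CC(C)=CCC/C(C)=C/CC/C(C)=C/CSC[C@H](NC(=O)CCCCCN1CCCC1)C(=O)NC1CC1` gives > 20000 nM, which is a limit of the assay and not a number. Compound 1 `CC(C)=CCC/C(C)=C/CC/C(C)=C/CSC[C@H](NC(=O)CCCCCN1CCCC1)C(=O)N1CCCCC1` gives 8700 nM in this assay.

The next compound, compound 3 `CC(C)=CCC/C(C)=C/CC/C(C)=C/CSC[C@H](NC(=O)CCCCCN1CCCC1)C(=O)N1CCCC1`, changes the same place: pyrrolidin-1-yl in place of cyclopropylamino on a carbonyl carbon. In words, pyrrolidin-1-yl stands in place of cyclopropylamino on a carbonyl carbon.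

Among the compounds with values here, only one measured step bears on this change. It is an at least 2.2-fold higher number from compound 1 to compound 2 (0.36 log units; beyond the scatter), beyond the scatter, with cyclopropylamino in place of piperidin-1-yl on a carbonyl carbon. The new change runs the opposite way, from cyclopropylamino to a similar ring bound through its nitrogen, so a lower number is expected. The expected step is an at least 2.0-fold lower number from compound 2 to compound 3 (0.30 log units; that floor lies within the scatter), and its true size stays uncertain while one end rests on a limit. Compound 3 is estimated at 10000 nM, with an expected range from 4500 nM to 20000 nM.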

Compound 3, half-maximal effective concentration: 6500 nM
The estimate for compound 3 lay 1.5-fold (0.19 log units) above the measured number, within the range that was stated.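

In this assay, the step between the two rings bound through their nitrogen is a 1.3-fold lower number from compound 1 to compound 3 (0.13 log units; within the scatter), so pyrrolidin-1-yl and piperidin-1-yl on this carbonyl carbon cannot be told apart. Putting pyrrolidin-1-yl in place of cyclopropylamino gives an at least 3.0-fold lower number from compound 2 to compound 3 (0.48 log units; beyond the scatter), so a second ring bound through its nitrogen now stands apart from cyclopropylamino, which carries the amide hydrogen, and the first step no longer rests on piperidin-1-yl alone. The size of this step rests on a limit of the assay for compound 2, not on a number: the limit of > 20000 nM in this assay, at which 1 of the 3 values shown sits.

Going by these compounds, how far compound 2 truly lies from compound 3 stays open. A dimethylamino group or a morpholin-4-yl ring on this carbonyl carbon would show whether the lower numbers go with a ring or with the loss of the amide hydrogen.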